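Aryl exchange on the ring nitrogen: notes toward compound 3

A few compounds are considered here, and "the series" means these few. Any claim that something is new, unique, unknown or untested is made for them only; others in the source may bear on it.

compound 1 `Cc1nc(-c2cccc(F)c2)c(C(=O)N2CCN(c3cccc(Cl)c3)CC2)o1` — 33.7 nM
compound 2 `Cc1nc(-c2ccccc2F)c(C(=O)N2CCN(c3cccc(Cl)c3)CC2)o1` — 39.4 nM

In a functional assay on HL-60 cells (Homo sapiens) for inhibition, read by MTT assay, with a stated time of 72 h (on this read-out lower numbers stand for stronger inhibition and higher numbers for weaker inhibition), compound 1 gives 33.7 nM, the lowest of the two numbers. Compound 2 gives 39.4 nM; the change is a 1.2-fold higher number from compound 1 to compound 2 (0.07 log units; within the scatter), which is within the scatter. Compound 3 `Cc1ccc(C)c(N2CCN(C(=O)c3oc(C)nc3-c3cccc(F)c3)CC2)c1` has not been measured. It differs from compound 1 by 2,5-dimethylphenyl in place of 3-chlorophenyl on an amine nitrogen in a ring. Among the measured compounds shown here, the only measured step, a 1.2-fold higher number from compound 1 to compound 2 (0.07 log units; within the scatter), concerns the fluorophenyl, not the amine nitrogen in a ring, so no measured step bears on this change, and the expected direction is open. A number near that of compound 1 is the working expectation. Compound 3 is estimated at 50 nM, range 15 nM to 200 nM. This estimate amounts to an expected step of a 1.5-fold higher number from compound 1 to compound 3 (0.17 log units; within the scatter).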

Compound 3, half-maximal inhibitory concentration: 204 nM
The estimate for compound 3 lay 4.1-fold (0.61 log units) below the measured number; the measured number lies above the stated range.
By their numbers in this assay, from the lowest: compounds 1 and 2 (each within the scatter of the next); then compound 3.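

In this assay, among the compounds shown here, the aryl group on the ring amine nitrogen proves sensitive: 2,5-dimethylphenyl in place of 3-chlorophenyl gives a 6.1-fold higher number from compound 1 to compound 3 (0.78 log units; beyond the scatter) and is the first step beyond the scatter. The fluorophenyl exchange had shown no such separation, so this position, not that one, is where the numbers have begun to move. No measurement available here accounts for the rise.

For the compounds shown here, the single exchange changes the whole substitution pattern at once, so the contribution of each methyl remains unresolved. A 3-methylphenyl or unsubstituted phenyl on that nitrogen remains an open case.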